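Swapping a phenyl for an ethyl on the ring nitrogen

A few compounds are considered here, and "the series" means these few. Any claim that something is new, unique, unknown or untested is made for them only; others in the source may bear on it.

Measured so far:
compound 1, `CC(C)(C)OC(=O)NCCCCCNC1=Nc2ccccc2C(CC(=O)NCc2ccccc2)N1c1ccc(-c2ccccc2)cc1`, 1640 nM;
compound 2, `O=C(CC1c2ccccc2N=C(N2CCCCC2)N1c1ccccc1)NCc1ccc(NS(=O)(=O)c2ccc(F)cc2)cc1`, 1710 nM;
compound 3, `CN(CCCCCN1CCCC1)C1=Nc2ccccc2C(CC(=O)NCc2ccccc2)N1c1ccc(-c2ccccc2)cc1`, 2490 nM.

These three compounds were tested in a functional assay on DU-145 cells (Homo sapiens) for inhibition, read by sulforhodamine B assay, with a stated time of 72 h; on this read-out lower numbers stand for stronger inhibition of growth and higher numbers for weaker inhibition of growth. Compound 2 stands second highest of the three numbers; its value sits within the usual scatter of compound 1 and also within the scatter of compound 3, so the three cannot be told apart on these data.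

Compound 4, `CCN1C(N2CCCCC2)=Nc2ccccc2C1CC(=O)NCc1ccc(NS(=O)(=O)c2ccc(F)cc2)cc1`, has not been measured. It differs from compound 2 in one place: ethyl in place of phenyl on an amine nitrogen in a ring. No pair of measured compounds differs in a single place, so nothing shown tells how a change on this ring nitrogen moves the read-out; all three measured compounds carry an aromatic ring there.

Without such a guide, a modest step toward weaker growth inhibition is expected for a 1.8-fold higher number from compound 2 to compound 4 (0.24 log units; within the scatter), with a wide range on either side. The estimate for compound 4 in this assay is 3000 nM, expected to fall between 700 nM and 12000 nM.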

Compound 4, concentration for 50% growth inhibition: 17200 nM
For compound 4 the middle estimate is 5.7-fold (0.76 log units) below the measured one; measured number outside the range, above it.
By their numbers in this assay, from the lowest: compounds 1, 2 and 3 (each within the scatter of the next); then compound 4.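

Going by these compounds alone, this is the first single change here that can be read, and it shows that the group on this ring nitrogen matters: in this assay, ethyl in place of phenyl gives a 10-fold higher number from compound 2 to compound 4 (1.00 log units; beyond the scatter). Neither group carries a hydrogen-bond donor, a hydrogen-bond acceptor or a net charge, so what differs by these counts is the number of carbons and the presence of the aromatic ring. Nothing available explains why growth inhibition weakens with this swap.

This one pair cannot separate the loss of the aromatic ring from the loss of carbons, and a cyclohexyl group or a longer chain such as butyl on this nitrogen would help to tell those apart. As far as these compounds go, it also remains open whether the same swap would move the number as far in compounds with another group on the shared core.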